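Chloro for methoxy on the pendant phenyl ring

The source may report more compounds than this note shows. Statements on the series, on what has been measured and on what is new or still open speak of the compounds shown alone.

Compound 2 `COc1cccc(C(O)CCn2nc3c(Br)c(Br)c(Br)c(Br)c3n2)c1` gives 97% in a functional assay on MCF7 cells (Homo sapiens) for antiproliferative activity, read by MTT assay, with a stated time of 48 h, tested at 12.5 uM (on this read-out higher numbers stand for a weaker effect at the one concentration tested and lower numbers for a stronger effect), the lowest of the two numbers shown; compound 1 `OC(CCn1nc2c(Br)c(Br)c(Br)c(Br)c2n1)c1cccc(Br)c1` gives 102%, and the step of a number 5 percentage points lower from compound 1 to compound 2 (within the scatter) lies within the scatter. Compound 3 `OC(CCn1nc2c(Br)c(Br)c(Br)c(Br)c2n1)c1cccc(Cl)c1` differs from compound 2 by chloro in place of methoxy on an aromatic carbon. Among the measured compounds shown here, the only measured step, from bromo to methoxy, was within the scatter, so the change to chloro is expected to give no step beyond the scatter: a number 3 percentage points higher from compound 2 to compound 3 (within the scatter). Compound 3 is therefore estimated at 100% in this assay, within the range 85% to 115%.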

Compound 3, a percentage reported as activity, at one concentration (the size of the read-out at that concentration, not a potency): 107%
Compound 3: middle estimate off by 7 percentage points, on the low side; the measured number falls inside the stated range.
By their numbers in this assay, from the lowest: compounds 2, 1 and 3 (each within the scatter of the next).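

At this position on the aromatic ring, meta to a large group, chloro now joins bromo and methoxy without separating from either in this assay: chloro in place of methoxy gives a number 10 percentage points higher from compound 2 to compound 3 (within the scatter), and chloro in place of bromo gives a number 5 percentage points higher from compound 1 to compound 3 (within the scatter). All three groups therefore read alike here, at the one concentration tested. Nothing available accounts for this flat result.

The compounds shown leave open whether an amine, a carboxylic acid or a longer chain at this position would give a step beyond the scatter. They also leave open whether any of these groups would do so elsewhere on the ring.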